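Aryl Hydrazone Variation and Antiproliferative Potency on a Shared Core

This account rests on a few compounds, and the source may have more. Where it says the series, first, only, none or still open, it means among the compounds named here.

Compound 1 `Cn1c(=O)c(=O)n(C2CCCC2)c2nc(N/N=C/c3ccc(O)cc3)ncc21`: > 100000 nM
Compound 2 `Cn1c(=O)c(=O)n(C2CCCC2)c2nc(N/N=C/c3ccco3)ncc21`: 72200 nM
Compound 3 `Cc1ccc(/C=N/Nc2ncc3c(n2)n(C2CCCC2)c(=O)c(=O)n3C)cc1C`: 39000 nM

Three compounds on the same core, differing only in the aryl group on a carbon with a double bond to nitrogen, have been measured in a functional assay on PC-3 cells (Homo sapiens) for antiproliferative activity, read by MTT assay; on this read-out lower numbers stand for stronger inhibition and higher numbers for weaker inhibition. Compound 1 gives no number at all, only the limit (the limit of > 100000 nM in this assay, at which 1 of the 3 values shown sits). Compound 3 gives the lowest of the two numbers obtained, yet a 1.9-fold lower number from compound 2 to compound 3 (0.27 log units; within the scatter), so compound 2 and compound 3 cannot be told apart. Against compound 1 the picture is firmer: an at least 2.5-fold lower number from compound 1 to compound 3 (0.40 log units; beyond the scatter).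

Compound 4 `Cn1c(=O)c(=O)n(C2CCCC2)c2nc(N/N=C/c3ccc(F)cc3F)ncc21` is the next member of the series. Compared with compound 3 it differs as follows: 2,4-difluorophenyl in place of 3,4-dimethylphenyl on a carbon with a double bond to nitrogen. The two measured steps that touch this position, the swap from 4-hydroxyphenyl and the swap from furan-2-yl to 3,4-dimethylphenyl, were modest at most, one beyond the scatter and one within it. A shift from 3,4-dimethylphenyl to 2,4-difluorophenyl is therefore expected to move the number little in this assay, with the step of a 1.3-fold higher number from compound 3 to compound 4 (0.11 log units; within the scatter) staying within the scatter. Compound 4 is estimated at 50000 nM, in a range from 18000 nM to 140000 nM.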

Compound 4, half-maximal inhibitory concentration: 13200 nM
Compound 4: middle estimate off by 3.8-fold (0.58 log units), on the high side; the measured number lies below the stated range.
By their numbers in this assay, from the lowest: compound 4; then compounds 3 and 2 (each within the scatter of the next). At a limit, above all of these: compound 1.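

In this assay this position proves able to separate two measured compounds, even though the groups exchanged have the same count of heavy atoms and neither carries a hydrogen-bond donor or acceptor (a 3.0-fold lower number from compound 3 to compound 4 (0.47 log units; beyond the scatter)). Within the data shown here, compound 4 also stands clear of the furan-2-yl compound, whereas compound 2 and compound 3 could not be told apart, so 2,4-difluorophenyl is the first group here to give a step beyond the scatter between two real numbers (a 5.5-fold lower number from compound 2 to compound 4 (0.74 log units; beyond the scatter)). Compound 1 remains a limit rather than a number, so the step to compound 4 from the 4-hydroxyphenyl compound (an at least 7.5-fold lower number from compound 1 to compound 4 (0.87 log units; beyond the scatter)) is only a floor: (the limit of > 100000 nM in this assay, at which 1 of the 4 values shown sits).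

The compounds shown leave open whether a single fluorine on the phenyl ring, or a chlorine or a methoxy group in place of the fluorines, would give a number like that of compound 4, and so whether the fluorine atoms themselves or their particular arrangement matter. They also leave open how an amine or a carboxylic acid on that ring would read in this assay, and whether any aryl group at this place on the shared core can reach a much lower number.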